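The source may hold more compounds than are shown below. What is called first, only, known or untested is meant among the compounds shown, and "the series" means these compounds.

The measured compounds and their numbers in an assay on Sf9 cells for inhibition of Leucine-rich repeat serine/threonine-protein kinase 2 (Homo sapiens), read by TR-FRET, with stated times of 30 min and 2 h; on this read-out higher numbers stand for weaker inhibition and lower numbers for stronger inhibition:

Compound 1, `O=C(Nc1cccc(Cl)c1)c1cc(C(F)(F)F)ccc1OCc1ccc(F)cc1`, gives 12.6 nM.
Compound 2, `N#Cc1cccc(NC(=O)c2cc(C(F)(F)F)ccc2OCc2ccc(F)cc2)c1`, gives 7.94 nM.
Compound 3, `O=C(Nc1ccnnc1)c1cc(N2CCNCC2)ccc1OCc1ccccc1`, gives 15.9 nM.

Compound 3 has the highest of the three numbers in this assay, but its gaps to compound 1 and to compound 2 both lie within the scatter, so none of the three can be separated from the others on these data. Among the measured compounds shown here, the one measured step, a 1.6-fold lower number from compound 1 to compound 2 (0.20 log units; within the scatter), is also within the scatter; it concerns the aromatic amide part of the shared core of compound 1 and compound 2 and not the part that changes here.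

Compound 4, `CN1CCC(c2ccc(OCc3ccccc3)c(C(=O)Nc3ccnnc3)c2)CC1`, differs from compound 3 in one place: 1-methylpiperidin-4-yl in place of piperazin-1-yl on an aromatic carbon. For the measured compounds named here, no measured step touches this position or this kind of exchange, so nothing in the data indicates a direction. With compound 3 at 15.9 nM as the only anchor, the expectation for compound 4 is a number of about the same size, and the expected step, a 1.3-fold lower number from compound 3 to compound 4 (0.12 log units; within the scatter), stays within the scatter. Compound 4 is therefore estimated at 12 nM in this assay, with a plausible range from 4 nM to 40 nM.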

Compound 4, half-maximal inhibitory concentration: 20 nM
Beside the measured number, compound 4's estimate is 1.7-fold (0.22 log units) below it; measured number inside the range.
By their numbers in this assay, from the lowest: compounds 2, 1, 3 and 4 (each within the scatter of the next, the first and the last beyond it).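

In this assay, among the compounds shown here, the exchange on the aromatic carbon para to a benzyloxy group and meta to a (pyridazin-4-yl)carbamoyl group gives a 1.3-fold higher number from compound 3 to compound 4 (0.10 log units; within the scatter), the first reading at this position. For this one pair, the two numbers cannot be separated, although 1-methylpiperidin-4-yl has 0 hydrogen-bond donors and one hetero atom in its ring, while piperazin-1-yl has 1 hydrogen-bond donor and 2 hetero atoms in its ring. The result therefore shows that this particular exchange, with the rest of the molecule held constant, leaves the number within the scatter, but nothing presented here accounts for that outcome.

The compounds shown leave open whether a morpholin-4-yl group, an open-chain amine or a carboxylic acid on the same aromatic carbon would also stay within the scatter of compound 3. They also leave open how a 4-methylpiperazin-1-yl or a piperidin-4-yl group would read there, and such a pair could set the added methyl apart from the exchange of the ring atom.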